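The source may report more compounds than this note shows. Statements on the series, on what has been measured and on what is new or still open speak of the compounds shown alone.

Compound 1, `CCC(C(=O)N1CCN(c2cccc(C(F)(F)F)c2)CC1)N1C(=O)CCC1=O`, gives 50% in a functional assay on the whole organism (strain Swiss) with Mus musculus as the target, in the maximal electroshock model, with a stated time of 2 h, at a dose of 300 mg/kg by the intraperitoneal route; on this read-out higher numbers stand for a stronger effect at the one dose given and lower numbers for a weaker effect. Compound 2, `CCC(C(=O)N1CCN(c2cccc(C)c2)CC1)N1C(=O)CCC1=O`, differs from it by methyl in place of trifluoromethyl on an aromatic carbon and gives 0% in this assay; that change made a number 50 percentage points lower from compound 1 to compound 2 (beyond the scatter). Compound 3, `CC(C(=O)N1CCN(c2cccc(C(F)(F)F)c2)CC1)N1C(=O)CCC1=O`, differs from compound 1 by hydrogen in place of methyl on a saturated chain carbon, two bonds along the chain from an amide-type nitrogen in a ring and a carbonyl carbon. In this assay compound 3 gives 100%, the step being a number 50 percentage points higher from compound 1 to compound 3 (beyond the scatter). Compound 3 therefore stands highest of the three, as both of its steps to the others lie beyond the usual scatter.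

Compound 4, `Cc1cccc(N2CCN(C(=O)C(C)N3C(=O)CCC3=O)CC2)c1`, has not yet been tested in this assay. Among the compounds with values here, it differs from compound 3 by methyl in place of trifluoromethyl on an aromatic carbon, which is the same change as the one from compound 1 to compound 2, made here on a different core; the two cores differ by hydrogen in place of methyl on a saturated chain carbon, two bonds along the chain from an amide-type nitrogen in a ring and a carbonyl carbon. Since that change once produced a number 50 percentage points lower from compound 1 to compound 2 (beyond the scatter), a drop of similar size is expected here as well, although compound 3 starts from a higher point and the read-out has a floor, so the exact size is uncertain. For compound 4 the expected step is a number 55 percentage points lower from compound 3 to compound 4 (beyond the scatter). Compound 4 is estimated at 45%, most likely between 0% and 90%.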

Compound 4, a percentage reported as activity, at one dose (the size of the read-out at that dose, not a potency): 0%
Estimate against measurement, compound 4: 45 percentage points above; the measured number falls inside the stated range.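

In this assay, methyl in place of trifluoromethyl gives a number 100 percentage points lower from compound 3 to compound 4 (beyond the scatter), so the direction seen on the core of compound 1 carries over to the second core, while the size of the step does not: the same change on two cores in this assay, a number 50 percentage points lower (beyond the scatter) from compound 1 to compound 2 and a number 100 percentage points lower (beyond the scatter) from compound 3 to compound 4, 50 percentage points apart, beyond the scatter of two such steps The change on the saturated chain, which raised the read-out with trifluoromethyl on the aromatic ring, gives no change at the digits printed from compound 2 to compound 4 (within the scatter) with methyl there, so its result also depends on the rest of the molecule: the same change on two cores in this assay, a number 50 percentage points higher (beyond the scatter) from compound 1 to compound 3 and no change at the digits printed (within the scatter) from compound 2 to compound 4, 50 percentage points apart, beyond the scatter of two such steps Compound 2 gives 0% and compound 4 gives 0%, the bottom of this scale, so the steps ending there may not show the full size of the loss, and two cores do not establish a rule for other cores.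

As far as these compounds go, it remains open whether a chlorine atom or a methoxy group at the same place on the aromatic ring would behave like trifluoromethyl or like methyl. A plain hydrogen or a longer chain, such as propyl, on the saturated chain carbon is also left open.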